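From 3-fluorobenzyl to cyclohexylmethyl: a step without readable precedent

This account rests on a few compounds, and the source may have more. Where it says the series, first, only, none or still open, it means among the compounds named here.

Measured in a physicochemical assay for solubility; on this read-out higher numbers stand for higher solubility and lower numbers for lower solubility:
Compound 1 `CNC(=O)c1cc(C(=O)NC2CC2)cn(Cc2ccc(OC)cc2)c1=O`: >= 143 ug/mL
Compound 2 `CNC(=O)c1cc(C(=O)NCCCC2CNCCO2)cn(Cc2ccccc2)c1=O`: >= 194 ug/mL
Compound 3 `CNC(=O)c1cc(C(=O)NC2CC2)cn(Cc2cccc(F)c2)c1=O`: >= 133 ug/mL

Each of these three values is a limit and not a number. Compound 3 stands at the limit >= 133 ug/mL.

Compound 4 `CNC(=O)c1cc(C(=O)NC2CC2)cn(CC2CCCCC2)c1=O` has not yet been measured. It carries cyclohexyl in place of 3-fluorophenyl on a saturated chain carbon bound to an aromatic nitrogen. The same difference reads 3-fluorobenzyl to cyclohexylmethyl.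

Within the data shown here, the only measured step at that place is a step that the two limits leave unreadable from compound 1 to compound 3, with 3-fluorophenyl in place of 4-methoxyphenyl. Among the measured compounds shown here, its size cannot be read, and no measured compound carries cyclohexyl. With no measured size or direction to draw on, the expected step of an at least 1.1-fold lower number from compound 3 to compound 4 (0.06 log units; that floor lies within the scatter) is none beyond the scatter in this assay. For compound 4 the estimated value is 115 ug/mL, with an expected range of 45 ug/mL to 140 ug/mL.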

Compound 4, solubility: >= 148 ug/mL
Compound 4 ended at the assay's limit; the forecaster's own chance of this, stated with the estimate: 55%; middle value at least 1.2-fold (0.10 log units) from the limit.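

The steps from compound 3 to compound 4 and from compound 1 to compound 4 cannot be read: in this assay all three compounds carry limits and not numbers. The compounds shown leave open whether cyclohexyl, 3-fluorophenyl and 4-methoxyphenyl at this place differ at all on this read-out.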